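Pyrimidine for Methylpyridine on a Benzoxazolone Ether

A few compounds are considered here, and "the series" means these few. Any claim that something is new, unique, unknown or untested is made for them only; others in the source may bear on it.

Measured compounds:
- Compound 1 `C[C@@H](Oc1cc2oc(=O)n(CCC(=O)O)c2cc1Cl)c1ccc(F)cn1`: 31 nm/s
- Compound 2 `Cc1ccc([C@@H](C)Oc2cc3oc(=O)n(CCC(=O)O)c3cc2Cl)nc1`: 22 nm/s
- Compound 3 `CCOc1cc2oc(=O)n(CCC(=O)O)c2cc1Cl`: < 10 nm/s

These three compounds share one core and differ only in the group on the side chain oxygen. In a physicochemical assay for permeability, using PAMPA (on this read-out lower numbers stand for lower permeability and higher numbers for higher permeability), compound 1 gives 31 nm/s and compound 2 gives 22 nm/s. Compound 3 gives only a limit, < 10 nm/s, in this assay. So compound 2 stands within the scatter of compound 1, the step of a 1.4-fold lower number from compound 1 to compound 2 (0.15 log units; within the scatter) being small, while the third value is a limit rather than a number (the limit of < 10 nm/s in this assay, at which 1 of the 3 values shown sits).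

Compound 4 `C[C@@H](Oc1cc2oc(=O)n(CCC(=O)O)c2cc1Cl)c1ncccn1` has not yet been measured. It differs from compound 2 by pyrimidin-2-yl in place of 5-methylpyridin-2-yl on a saturated chain carbon bound to an oxygen on an aromatic ring and a saturated chain carbon.

Going by the values given here, the steps that bear on this change are an at least 2.2-fold lower number from compound 2 to compound 3 (0.34 log units; beyond the scatter) and an at least 3.1-fold lower number from compound 1 to compound 3 (0.49 log units; beyond the scatter): removing the whole aromatic group from the chain carbon drops the number to the limit. The step of a 1.4-fold lower number from compound 1 to compound 2 (0.15 log units; within the scatter) shows that swapping one small group on that aromatic ring changes little. Swapping the whole ring for pyrimidin-2-yl is a larger change than that, so a modest drop is expected, a 1.8-fold lower number from compound 2 to compound 4 (0.26 log units; within the scatter), with a fair chance of reaching the limit.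

Compound 4 is therefore estimated at 12 nm/s in this assay, expected between 6 nm/s and 25 nm/s.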

Compound 4, apparent permeability: < 3 nm/s
Compound 4 gave a limit, no number; the forecaster's own chance of this, stated with the estimate: 35%; middle value at least 4.0-fold (0.60 log units) away from the limit.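

Exchanging the ring on the chain carbon has a far larger effect in this assay than changing a small group on it: replacing 5-methylpyridin-2-yl with pyrimidin-2-yl gives an at least 7.3-fold lower number from compound 2 to compound 4 (0.86 log units; beyond the scatter), and replacing 5-fluoropyridin-2-yl with it gives an at least 10-fold lower number from compound 1 to compound 4 (1.01 log units; beyond the scatter), whereas putting methyl in place of fluoro gave only a 1.4-fold lower number from compound 1 to compound 2 (0.15 log units; within the scatter). The earlier compounds shown here showed only that removing the whole aromatic group lowers the number, while compound 4 shows that an aromatic ring at this position does not by itself keep the number up. The value of compound 4 is a limit, not a number: the limit of < 3 nm/s in this assay, at which 1 of the 4 values shown sits.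

On these data alone, compound 3 also gives a limit, so the step from compound 3 to compound 4 cannot be read, and how pyrimidin-2-yl compares with hydrogen at this position stays open. Compound 4 also differs from compound 1 and compound 2 by lacking a group on the ring, so a 5-methylpyrimidin-2-yl group on the same chain carbon would be needed to separate the effect of the added ring nitrogen from the effect of losing the methyl.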